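The compounds below may be only part of what the source reports. "The series", "measured", "known", "first", "only" and "open" are said of these compounds alone.

Among the compounds with values here, compound 1 `COc1ccc(C#Cc2ccc(C(=O)N3CC[C@@H](O)C3)cc2)cc1` is the one compound of the three with a number in a functional assay on TREX cells for negative allosteric modulation of metabotropic glutamate receptor 3 (Rattus norvegicus), read by calcium flux, with a stated time of 2.5 min; on this read-out lower numbers stand for stronger inhibition and higher numbers for weaker inhibition: compound 1 gives 10200 nM. Compound 2 `CSc1ccc(C#Cc2ccc(C(=O)N3CCC[C@@H](CO)C3)cc2)cc1` gives only a limit in this assay, > 10000 nM. Compound 3 `COc1ccc(C#Cc2ccc(C(=O)N3CCC[C@@H](CO)C3)cc2)cc1F` likewise gives only a limit, > 10000 nM. Within the data shown here, the step from compound 2 to compound 3 is a step that the two limits leave unreadable from compound 2 to compound 3, so the limit of > 10000 nM in this assay, at which 2 of the 3 values shown sit, is all the measured steps show. Compound 4 `COc1ccc(C#Cc2ccc(C(=O)N3CC4CCC(=O)C4C3)cc2)cc1` differs from compound 1 by a group of 9 heavy atoms (7 carbon, 1 nitrogen, 1 oxygen; one five-membered non-aromatic ring of carbon only, one five-membered non-aromatic ring with 1 hetero atom) in place of a group of 6 heavy atoms (4 carbon, 1 nitrogen, 1 oxygen; one five-membered non-aromatic ring with 1 hetero atom), on a carbonyl carbon. Among the measured compounds shown here, no measured step touches the group on the carbonyl carbon, so nothing speaks for a move beyond the scatter in this assay, and compound 1 already sits close to the limit. Compound 4 is therefore expected to move by a 1.0-fold lower number from compound 1 to compound 4 (0.01 log units; within the scatter). The estimate for compound 4 is 10000 nM, range 3000 nM to 30000 nM, with a fair chance that only a limit is returned.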

Compound 4, half-maximal inhibitory concentration: 2750 nM
The estimate for compound 4 lay 3.6-fold (0.56 log units) above the measured number; measured number below the stated range.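

In this assay, the change on the carbonyl carbon gives a 3.7-fold lower number from compound 1 to compound 4 (0.57 log units; beyond the scatter), so this position responds to substitution. Compound 4 lacks the 3-hydroxypyrrolidin-1-yl group and still gives a number, so that group is not required for inhibition in the compounds shown. The only other measured step cannot be read, and the group on the carbonyl carbon is the one place where a change registers: the limit of > 10000 nM in this assay, at which 2 of the 4 values shown sit.

Within the data shown here, the single step changes the hydroxyl and the ring count together, so their contributions remain unseparated. From the compounds shown here alone, how an amine or a carboxylic acid in the group on the carbonyl carbon would read remains open.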